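Removing Chloro on the Pendant Ring in Paw Edema

The compounds below may be only part of what the source reports. "The series", "measured", "known", "first", "only" and "open" are said of these compounds alone.

Of the compounds shown here, three have so far been measured in a functional assay on the whole organism (strain Wistar) for inhibition, with Rattus norvegicus as the target, read by paw edema, with stated times of 3 h and 1 h, at a dose of 6 mg/kg by the oral route; on this read-out higher numbers stand for more inhibition at the one dose given (going by the name of the read-out) and lower numbers for less inhibition. Compound 1, `O=C(CO[N+](=O)[O-])NNC(=O)c1ccc(-n2[nH]c(=O)cc2-c2ccc(Cl)cc2)cc1`, gives 5.84% in this assay. Compound 2, `O=C(CO[N+](=O)[O-])NNC(=O)c1ccc(-n2[nH]c(=O)cc2-c2ccccc2)cc1`, gives 20.5% in this assay. Compound 3, `CCOC(=O)c1c(-c2ccc(Cl)cc2)n(-c2ccc(C(=O)NNC(=O)CO[N+](=O)[O-])cc2)[nH]c1=O`, gives 6.43% in this assay. Compound 1 and compound 2 differ by hydrogen in place of chloro on an aromatic carbon, and this change brought a number 14.7 percentage points higher from compound 1 to compound 2 (beyond the scatter). The core of compound 3 differs from the core of compound 1 by ethoxycarbonyl in place of hydrogen on an aromatic carbon, and that change brought a number 0.6 percentage points higher from compound 1 to compound 3 (within the scatter), so compound 1 and compound 3 sit together in this assay, while compound 2 stands apart from both.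

Compound 4, `CCOC(=O)c1c(-c2ccccc2)n(-c2ccc(C(=O)NNC(=O)CO[N+](=O)[O-])cc2)[nH]c1=O`, has not yet been measured. Going by the values given here, it differs from compound 3 by hydrogen in place of chloro on an aromatic carbon, which is the same change as the one from compound 1 to compound 2, made at a place described in the same words. Among the compounds with values here, the only measured instance of this change is the single step from compound 1 to compound 2, so the expectation rests on one pair. The step from compound 3 to compound 4 is expected to be of a similar size, a number 12.6 percentage points higher from compound 3 to compound 4 (beyond the scatter), because the core of compound 3 behaved like that of compound 1 in the step of a number 0.6 percentage points higher from compound 1 to compound 3 (within the scatter). Compound 4 is therefore expected to give about 19% in this assay. The range for compound 4 is estimated to run from 6% to 32%, and it is set wide.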

Compound 4, a percentage reported as inhibition, in the whole organism at one dose (the size of the read-out at that dose, not a potency): 59.6%
Compound 4: the middle estimate sits 40.6 percentage points below what was measured; the whole stated range lies below it.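

In this assay, the change from 4-chlorophenyl to phenyl raised the number on both cores, but its size did not carry over, and on the core bearing ethoxycarbonyl it gave a number 53.2 percentage points higher from compound 3 to compound 4 (beyond the scatter), so the two instances differ: the same change on two cores in this assay, a number 14.7 percentage points higher (beyond the scatter) from compound 1 to compound 2 and a number 53.2 percentage points higher (beyond the scatter) from compound 3 to compound 4, 38.5 percentage points apart, beyond the scatter of two such steps

The ethoxycarbonyl change likewise depended on the group already present, giving a number 39.1 percentage points higher from compound 2 to compound 4 (beyond the scatter) where the ring is phenyl, whereas it made no difference beyond the scatter where the ring is 4-chlorophenyl: the same change on two cores in this assay, a number 0.6 percentage points higher (within the scatter) from compound 1 to compound 3 and a number 39.1 percentage points higher (beyond the scatter) from compound 2 to compound 4, 38.5 percentage points apart, beyond the scatter of two such steps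

The two changes therefore do not add up in these four compounds, and the loss of chloro raised the number in both pairs, but two pairs give no rule for other cores and do not show why the steps differ so widely.

The compounds shown leave open whether fluoro, methyl or methoxy on that ring would behave like hydrogen or like chloro, and whether a carboxylic acid or a primary amide in place of ethoxycarbonyl would keep the high number of compound 4. They also leave open how compound 4 would behave at other oral doses, since each compound here is described at a single dose.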